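Swapping 4-methylphenyl for 2-nitrophenyl among weak inhibitors

A few compounds are considered here, and "the series" means these few. Any claim that something is new, unique, unknown or untested is made for them only; others in the source may bear on it.

In a physicochemical assay, with a stated time of 6 min (a lower number here means a stronger inhibitor, a higher number a weaker inhibitor), compound 1 `O=C(Nc1ccc(I)cc1)Nc1nc(-c2cc3ccccc3o2)cs1` gives 62000 nM and compound 3 `O=C(Nc1ccccc1)Nc1nc(-c2cc3cc([N+](=O)[O-])ccc3o2)cs1` gives 183000 nM. Compound 2 `Cc1ccc(NC(=O)Nc2nc(-c3cc4cc(Br)ccc4o3)cs2)cc1` gives > 200000 nM, which is a limit of the assay and not a number. Compound 4 `O=C(Nc1nc(-c2cc3cc(Br)ccc3o2)cs1)Nc1ccccc1[N+](=O)[O-]` keeps the core of compound 2 but carries 2-nitrophenyl in place of 4-methylphenyl on an amide-type nitrogen. Going by the values given here, no two measured compounds differ in only one place, so the size of this change cannot be read directly from the data. The expected result is a modest move towards a stronger inhibitor, given as an estimated at least 1.3-fold lower number from compound 2 to compound 4 (0.12 log units; that floor lies within the scatter). For compound 4, the estimated value is 150000 nM, with an expected range from 60000 nM to 400000 nM.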

Compound 4, half-maximal inhibitory concentration: 166000 nM
Compound 4: the middle estimate sits 1.1-fold (0.04 log units) below what was measured, within the range that was stated.
By their numbers in this assay, from the lowest: compound 1; then compounds 4 and 3 (each within the scatter of the next). At a limit, above all of these: compound 2.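

In this assay, placing 2-nitrophenyl instead of 4-methylphenyl on the amide-type nitrogen gives an at least 1.2-fold lower number from compound 2 to compound 4 (0.08 log units; that floor lies within the scatter). This first one-place comparison shows that the core of compound 2 can give a readable value with this change, yet the floor alone does not show how large the true step is. Compound 2 has only a limit, not a number: the limit of > 200000 nM in this assay, at which 1 of the 4 values shown sits.

Still open, from the compounds shown here alone, is how far this position can move the value in either direction. An amine or a carboxylic acid on the phenyl ring here might give a different result.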